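The compounds below may be only part of what the source reports. "The series", "measured", "known", "first", "only" and "open" are said of these compounds alone.

Measured compounds and their numbers in paw-edema inhibition:
compound 1 `CNC(=O)CC1CCc2cc(OC)c(OC)cc21`: 24.1%
compound 2 `COc1cc2c(cc1OC)C(CC(=O)NC(C)C)CC2`: 37%
compound 3 `CCCCCCNC(=O)CC1CCc2cc(OC)c(OC)cc21`: 38.3%

In a functional assay on the whole organism (strain Wistar) for inhibition, with Rattus norvegicus as the target, read by paw edema, with stated times of 60 min and 6 h, at a dose of 100 mg/kg by the oral route (on this read-out lower numbers stand for less inhibition and higher numbers for more inhibition at the one dose given (going by the name of the read-out)), compound 3 carries the top number of the three, yet it is not set apart from compound 2, as a number 1.3 percentage points higher from compound 2 to compound 3 (within the scatter) shows; only against compound 1 does it stand clear, as a number 14.2 percentage points higher from compound 1 to compound 3 (beyond the scatter) shows. Compound 4 `COc1cc2c(cc1OC)C(CC(=O)NCc1ccccc1)CC2` differs from compound 3 by phenyl in place of pentyl on a saturated chain carbon bound to an amide-type nitrogen. Among the measured compounds shown here, no measured step swaps a chain for a ring at this place; the steps at the same amide-type nitrogen are a number 14.2 percentage points higher from compound 1 to compound 3 (beyond the scatter) and a number 1.3 percentage points higher from compound 2 to compound 3 (within the scatter), one modest and one within the scatter. For compound 4 the expected step is therefore a number 0.3 percentage points lower from compound 3 to compound 4 (within the scatter), not beyond the scatter. Compound 4 is estimated at 38%, with a range from 26% to 50%.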

Compound 4, a percentage reported as inhibition, in the whole organism at one dose (the size of the read-out at that dose, not a potency): 30.6%
Compound 4: middle estimate off by 7.4 percentage points, on the high side, within the range that was stated.
By their numbers in this assay, from the lowest: compounds 1, 4, 2 and 3 (each within the scatter of the next, the first and the last beyond it).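

In this assay the benzyl amide, the only aromatic ring at this place, is not set apart from any of the alkyl amides: a number 7.7 percentage points lower from compound 3 to compound 4 (within the scatter), a number 6.4 percentage points lower from compound 2 to compound 4 (within the scatter) and a number 6.5 percentage points higher from compound 1 to compound 4 (within the scatter) all lie within the scatter. At this one dose, phenyl in place of pentyl on a saturated chain carbon bound to an amide-type nitrogen gives no readable change. No other measurement bears on this result. Open, on these data alone, is whether a chain longer than hexyl on the amide-type nitrogen would stand clear of compound 3. Also open, as far as these compounds go, is what an amine or a carboxylic acid on the phenyl ring of compound 4 would give.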